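The source may hold more compounds than are shown below. What is called first, only, known or untested is meant among the compounds shown, and "the series" means these compounds.

Of the compounds shown here, two have been measured. Compound 1 `CCCCOC(=O)CC1c2cccc(C)c2S(=O)(=O)N1C(=O)c1ccc(Cl)cc1` gives in an assay on HEK-Blue hNOD1 cells for antagonist activity at Nucleotide-binding oligomerization domain-containing protein 1 (Homo sapiens), read by reporter gene assay, with stated times of 3 h and 20 h (on this read-out higher numbers stand for weaker inhibition and lower numbers for stronger inhibition), 2140 nM. Compound 2 `CCCCOC(=O)CC1c2cccc(C)c2S(=O)(=O)N1C(=O)c1ccc(C(F)(F)F)cc1` gives in this assay 1310 nM. The step of a 1.6-fold lower number from compound 1 to compound 2 (0.21 log units; within the scatter) is within the scatter, so although compound 2 shows the smaller of the two numbers, it cannot be called the stronger inhibitor.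

Compound 3 `CCCCOC(=O)CC1c2cccc(Cl)c2S(=O)(=O)N1C(=O)c1ccc(C(F)(F)F)cc1` differs from compound 2 by chloro in place of methyl on an aromatic carbon. Within the data shown here, the only measured step, a 1.6-fold lower number from compound 1 to compound 2 (0.21 log units; within the scatter), concerns a change on the other aromatic ring and so does not bear on this swap on the core. Among the measured compounds shown here, no measured step covers the core position that changes here. With nothing to point in either direction, no step beyond the scatter is expected in this assay. Compound 3 is therefore expected to give 1300 nM, within 500 nM to 3500 nM. The expected step of a 1.0-fold lower number from compound 2 to compound 3 (0.00 log units; within the scatter) is thus estimated to fall within the scatter.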

Compound 3, half-maximal inhibitory concentration: 1630 nM
Beside the measured number, compound 3's estimate is 1.3-fold (0.10 log units) below it; the range from low to high includes it.
By their numbers in this assay, from the lowest: compounds 2, 3 and 1 (each within the scatter of the next).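

In this assay, the core position now has a measured step of its own, with chloro in place of methyl on an aromatic carbon: a 1.2-fold higher number from compound 2 to compound 3 (0.09 log units; within the scatter). At this place on the six-membered aromatic ring, the two groups cannot be told apart in this read-out, and neither compound 2 nor compound 3 can be called the stronger inhibitor. No evidence on the cause accompanies this result.

The compounds shown leave open whether any other group at this position, such as a methoxy group, an amine or a carboxylic acid, would give a step beyond the scatter. They also leave open what the butyl ester contributes, as every compound shown carries it, and a shorter chain or a free carboxylic acid in its place remains untested here.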